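Changing the Amide Substituent Ahead of the Next Measurement

The source may hold more compounds than are shown below. What is called first, only, known or untested is meant among the compounds shown, and "the series" means these compounds.

Of the compounds shown here, two built on the same core have been measured in an assay on isolated protein for inhibition of histone deacetylase 4 (Homo sapiens), with a stated time of 1 h; a lower number here means a stronger inhibitor, a higher number a weaker inhibitor. Compound 1 `O=C(COc1ccc2cc(/C=C3/SC(=O)NC3=O)ccc2c1)Nc1cccc(C(F)(F)F)c1` gives 2500 nM. Compound 2 `Cc1cccc2sc(NC(=O)COc3ccc4cc(/C=C5/SC(=O)NC5=O)ccc4c3)nc12` gives 1200 nM. Within the data shown here, the single change between them, a 2.1-fold lower number from compound 1 to compound 2 (0.32 log units; beyond the scatter), is the only step known so far, and it leaves compound 2 with the lower of the two numbers.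

Compound 3 `COc1ccc(NC(=O)COc2ccc3cc(/C=C4/SC(=O)NC4=O)ccc3c2)cc1` is the next candidate. Relative to compound 2 it carries 4-methoxyphenyl in place of 4-methyl-1,3-benzothiazol-2-yl on an amide-type nitrogen. Among the measured compounds shown here, no measured step covers this exact exchange. For the measured compounds named here, the one step available, a 2.1-fold lower number from compound 1 to compound 2 (0.32 log units; beyond the scatter), shows that replacing a substituted phenyl ring on the amide nitrogen with 4-methyl-1,3-benzothiazol-2-yl lowered the number modestly; compound 3 moves back to a substituted phenyl ring, though with 4-methoxyphenyl rather than 3-(trifluoromethyl)phenyl, so the number is expected to drift back toward that of compound 1, by a step about as large as that one or smaller. This corresponds to an expected 1.8-fold higher number from compound 2 to compound 3 (0.26 log units; within the scatter). Compound 3 is estimated at 2200 nM, with a likely range from 800 nM to 7000 nM.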

Compound 3, half-maximal inhibitory concentration: 4700 nM
For compound 3 the middle estimate is 2.1-fold (0.33 log units) below the measured one, within the range that was stated.
By their numbers in this assay, from the lowest: compound 2; then compounds 1 and 3 (each within the scatter of the next).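

The result shows that the lower number of compound 2 does not carry over to a second substituted phenyl ring on the amide nitrogen: there is a 3.9-fold higher number from compound 2 to compound 3 (0.59 log units; beyond the scatter) when 4-methoxyphenyl replaces 4-methyl-1,3-benzothiazol-2-yl. The two substituted phenyl compounds cannot be told apart in this assay, since a 1.9-fold higher number from compound 1 to compound 3 (0.27 log units; within the scatter) when 4-methoxyphenyl replaces 3-(trifluoromethyl)phenyl, so among the three compounds shown, the 4-methyl-1,3-benzothiazol-2-yl group alone stands apart at this position, while exchanging one phenyl substituent for the other makes no readable difference. Nothing at hand accounts for this difference between the groups.

The compounds shown leave open whether the methyl group matters or the fused ring system alone is enough, a question that 1,3-benzothiazol-2-yl without the methyl would address directly. They also leave open how a plain unsubstituted phenyl ring, a pyridine ring, or a phenyl ring carrying a carboxylic acid or an amine would compare on this same amide nitrogen, with the rest of the molecule unchanged.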